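Amino to Nitro on a Shared Indole-Free Core? No—Shared Core Step

A few compounds are considered here, and "the series" means these few. Any claim that something is new, unique, unknown or untested is made for them only; others in the source may bear on it.

Measured so far in an assay on isolated protein for inhibition of Aromatase (Homo sapiens), read by fluorescence, using NADPH, with a stated time of 30 min, tested at 50 uM; a lower number here means less inhibition, a higher number more inhibition at the concentration tested (going by the name of the read-out):
compound 1 `C#Cc1c(-c2ccccc2)[nH]c2ccccc12` gives 88%;
compound 2 `Nc1ccc2[nH]c(-c3ccccc3)cc2c1` gives 41.4%;
compound 3 `O/N=C/c1c(-c2ccccc2)[nH]c2ccccc12` gives 40.4%.

Compound 2 sits far below compound 1 and level with compound 3, its nearest neighbour, whose number lies within the usual scatter of it. Within the data shown here, the one step that can be compared directly, a number 47.6 percentage points lower from compound 1 to compound 3 (beyond the scatter), concerns a different position on the shared core and a different kind of exchange, so it does not bear on the change considered here; it only shows that a single substituent change on this core can shift the read-out strongly.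

Compound 4 `O=[N+]([O-])c1ccc2[nH]c(-c3ccccc3)cc2c1` differs from compound 2 by nitro in place of amino on an aromatic carbon. Among the measured compounds shown here, no measured pair shows what happens when nitro replaces amino at this place, so the direction of any shift is not known from these data. The expectation for compound 4 is therefore a step of a number 3.6 percentage points higher from compound 2 to compound 4 (within the scatter) in this assay, with wide uncertainty to either side. Compound 4 is estimated to give 45%, expected between 20% and 72%.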

Compound 4, a percentage reported as inhibition, at one concentration (the size of the read-out at that concentration, not a potency): 77.7%
Compound 4: the middle estimate sits 32.7 percentage points below what was measured, outside the stated range (above it).
By their numbers in this assay, from the lowest: compounds 3 and 2 (each within the scatter of the next); then compound 4; then compound 1.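

Changing this aromatic carbon, meta to one fused ring and para to the other, moves the read-out strongly in this assay, with a number 36.3 percentage points higher from compound 2 to compound 4 (beyond the scatter), so this position is sensitive to the group it carries. Until now, the only large shift on the shared core was at a different place, a number 47.6 percentage points lower from compound 1 to compound 3 (beyond the scatter), and that step said nothing about this position or this exchange. Here the entering nitro has 0 hydrogen-bond donors and 2 hydrogen-bond acceptors, against 1 hydrogen-bond donor and 1 hydrogen-bond acceptor for the leaving amino, but nothing shown gives a reason for the step or separates these differences from one another.

As far as these compounds go, whether the high number belongs to nitro in particular stays open, and a nitrile or a carboxylic acid on the same aromatic carbon would help to settle that. Also open, from the compounds shown here alone, is how the two compounds compare in potency, since each number comes from a single tested concentration and a full concentration series would be needed to rank them that way.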